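The source may report more compounds than this note shows. Statements on the series, on what has been measured and on what is new or still open speak of the compounds shown alone.

In a functional assay on DU-145 cells (Homo sapiens) for inhibition, read by trypan blue exclusion, with a stated time of 96 h (on this read-out higher numbers stand for weaker inhibition of growth and lower numbers for stronger inhibition of growth), compound 3 `O=C(/C(=C\c1ccc(Br)cc1)S(=O)(=O)c1ccc(Br)cc1)c1ccc(Br)cc1` gives 10000 nM, the lowest number of the three measured, against compound 2 `O=C(/C(=C\c1ccc(F)c([N+](=O)[O-])c1)S(=O)(=O)c1ccc(Br)cc1)c1ccc(Br)cc1` at 25000 nM and compound 1 `O=C(/C(=C\c1ccc(Cl)cc1)S(=O)(=O)c1ccc(Br)cc1)c1ccc(Br)cc1` at 50000 nM. Compound 4 `COc1ccc(S(=O)(=O)/C(=C/c2ccc(Br)cc2)C(=O)c2ccc(Br)cc2)cc1` differs from compound 3 by methoxy in place of bromo on an aromatic carbon. For the measured compounds named here, no measured step covers this place. The closest guides are changes elsewhere in the series: a 5.0-fold lower number from compound 1 to compound 3 (0.70 log units; beyond the scatter) and a 2.5-fold lower number from compound 2 to compound 3 (0.40 log units; beyond the scatter), both modest, while a 2.0-fold lower number from compound 1 to compound 2 (0.30 log units; within the scatter) stays within the scatter. A step within the scatter is therefore expected in this assay, with its direction unsettled. The estimated step is a 1.5-fold higher number from compound 3 to compound 4 (0.18 log units; within the scatter). The estimate for compound 4 is 15000 nM, with an expected range of 4000 nM to 50000 nM.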

Compound 4, concentration for 50% growth inhibition: 6000 nM
The estimate for compound 4 lay 2.5-fold (0.40 log units) above the measured number; measured number inside the range.
By their numbers in this assay, from the lowest: compounds 4 and 3 (each within the scatter of the next); then compounds 2 and 1 (each within the scatter of the next).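

In this assay, for the compounds shown here, methoxy in place of bromo at this position gives a 1.7-fold lower number from compound 3 to compound 4 (0.22 log units; within the scatter), the first reading at this place. An oxygen-linked group with one hydrogen-bond acceptor is therefore tolerated here, and bromo is not needed to keep the number of compound 3. No measurement available explains this result.

Open, from the compounds shown here alone, is whether an amine or a carboxylic acid at this position would stay within the scatter of compound 3. Also open, going by these compounds, is whether a longer chain such as propoxy would.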